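Lactam for phenoxy at the fused-core aromatic carbon

The source may report more compounds than this note shows. Statements on the series, on what has been measured and on what is new or still open speak of the compounds shown alone.

Compound 1 `Fc1ccc2c(c1CNc1ncc(Oc3ccccc3)c3nncn13)CCO2` stands lowest of the two measured numbers: in a physicochemical assay for solubility, read by LC-MS, in phosphate buffer, with a stated time of 24 h, at pH 7.4 (on this read-out higher numbers stand for higher solubility and lower numbers for lower solubility), compound 1 gives 8000 nM, while compound 2 `Cc1ncccc1-c1cnc(NCc2c(F)ccc3c2CCO3)c2ncc(=O)[nH]c12` gives 29000 nM, a gap beyond the scatter. Compound 3 `C[C@H]1CC(=O)N(c2cnc(NCc3c(F)ccc4c3CCO4)n3cnnc23)C1` is the unmeasured follow-on; it differs from compound 1 by 4-methyl-2-oxopyrrolidin-1-yl in place of phenoxy on an aromatic carbon. For the measured compounds named here, no step between measured compounds of this kind is available, so the expectation rests on compound 1 alone at 8000 nM. The step is expected to run upward, beyond the scatter, at a 5.0-fold higher number from compound 1 to compound 3 (0.70 log units; beyond the scatter). Compound 3 is estimated at 40000 nM, with a range from 12000 nM to 130000 nM.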

Compound 3, solubility: 200000 nM
Compound 3: the middle estimate sits 5.0-fold (0.70 log units) below what was measured; measured number above the stated range.
By their numbers in this assay, from the lowest: compound 1; then compound 2; then compound 3.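

Replacing phenoxy with 4-methyl-2-oxopyrrolidin-1-yl on this aromatic carbon gives a 25-fold higher number from compound 1 to compound 3 (1.40 log units; beyond the scatter) in this assay on the shared core, so this position can move the read-out strongly. The two groups match in heavy atoms, hydrogen-bond donors and hydrogen-bond acceptors, and differ in ring type and the defined stereocentre. No measurement at hand accounts for the step. Still open, on these data alone, is whether 2-oxopyrrolidin-1-yl without the methyl, the opposite stereocentre, or an open-chain amide or morpholine at this carbon would stand near compound 3.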